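Swapping a Saturated Ring for an Aromatic One

The compounds below may be only part of what the source reports. "The series", "measured", "known", "first", "only" and "open" are said of these compounds alone.

Measured compounds:
- compound 1, `O=C(Nc1ccc(NCC2CCNCC2)cc1Cl)c1cc(Cl)ccc1O`: "not determined" (no result reported) in an ADME assay on A549 cells (Homo sapiens) for cytotoxicity, read by LDH release, with a stated time of 15 h; on this read-out higher numbers stand for lower toxicity in this test and lower numbers for higher toxicity in this test
- compound 2, `O=C(Nc1ccc(NCC2CCCC2)cc1Cl)c1cc(Cl)ccc1O`: 141000 nM
- compound 3, `O=C(Nc1ccc(NCc2cc(C(F)(F)F)cc(C(F)(F)F)c2)cc1Cl)c1cc(Cl)ccc1O`: 22900 nM

Among the two numbers available, compound 2 stands highest, so it is the least toxic in this assay; compound 3 gives the lower number, and that gap lies beyond the usual scatter. Compound 1 has a single result withheld, so it cannot be placed.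

Compound 4, `O=C(Nc1ccc(NCc2ccccc2)cc1Cl)c1cc(Cl)ccc1O`, has not yet been measured. It differs from compound 2 in one place: phenyl in place of cyclopentyl on a saturated chain carbon bound to a nitrogen on an aromatic ring. For the measured compounds named here, no measured pair covers exactly this change, so its size has to be guessed from the spread of the two known values. The expectation is that compound 4 stays close to compound 2, with a small shift toward a lower number that is estimated to fall within scatter, as a 1.6-fold lower number from compound 2 to compound 4 (0.19 log units; within the scatter). For compound 4 the estimate in this assay is therefore 90000 nM, with a range from 30000 nM to 250000 nM.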

Compound 4, half-maximal cytotoxic concentration: 81300 nM
Compound 4: the middle estimate sits 1.1-fold (0.04 log units) above what was measured; the measured number falls inside the stated range.
By their numbers in this assay, from the lowest: compound 3; then compounds 4 and 2 (each within the scatter of the next).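

In this assay, phenyl in place of cyclopentyl on a saturated chain carbon bound to a nitrogen on an aromatic ring gives a step that can be read directly (a 1.7-fold lower number from compound 2 to compound 4 (0.24 log units; within the scatter)). For the compounds shown here, this is the first one-place comparison at this position, and it shows that a five-membered non-aromatic ring and a six-membered aromatic ring, both of carbon only, cannot be told apart here beyond the usual scatter. No measurement shown explains why the two rings read so alike.

Going by these compounds alone, this single pair covers only one swap, at one position and in one test. From the compounds shown here alone, how a pyridyl ring in place of the phenyl, or a phenethyl group in place of the benzyl, would read in this assay remains open.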